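Removing a side chain from compound 3

A few compounds are considered here, and "the series" means these few. Any claim that something is new, unique, unknown or untested is made for them only; others in the source may bear on it.

Measured so far in a functional assay on HeLa cells (Homo sapiens) for cytotoxicity, read by MTT assay, with a stated time of 72 h; on this read-out lower numbers stand for stronger inhibition and higher numbers for weaker inhibition:
compound 1 `CC(C)(C)C1=CC(=O)C=C(NCCC(=O)O)C1=O` gives 47100 nM
compound 2 `CC(C)(C)C1=CC(=O)C=C(NCC(=O)O)C1=O` gives 132000 nM
compound 3 `CSCC[C@H](NC1=CC(=O)C=C(C[C@]2(C)[C@@H](C)CC[C@]3(C)C(C)=CCC[C@@H]23)C1=O)C(=O)O` gives 13900 nM

Of these three, compound 3 gives the lowest number. Compound 4 `CC1=CCC[C@H]2[C@](C)(CC3=CC(=O)C=C(NCC(=O)O)C3=O)[C@@H](C)CC[C@]12C` remains unmeasured. The change hydrogen in place of 2-(methylsulfanyl)ethyl on a saturated chain carbon bound to an amine nitrogen and a carbonyl carbon reads in words as hydrogen in place of 2-(methylsulfanyl)ethyl on a saturated chain carbon bound to an amine nitrogen and a carbonyl carbon. Going by the values given here, only one measured step bears on this, and only loosely: the step of a 2.8-fold higher number from compound 1 to compound 2 (0.45 log units; beyond the scatter) is a different change, carboxy in place of carboxymethyl. A modest rise of like size is therefore expected in this assay on this thin basis. The expected step is a 2.2-fold higher number from compound 3 to compound 4 (0.33 log units; beyond the scatter) as estimated here. For compound 4 the estimate is 30000 nM with 11000 nM to 80000 nM as the expected range.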

Compound 4, half-maximal inhibitory concentration: 19900 nM
Compound 4: the middle estimate sits 1.5-fold (0.18 log units) above what was measured, within the range that was stated.
By their numbers in this assay, from the lowest: compounds 3 and 4 (each within the scatter of the next); then compound 1; then compound 2.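

In this assay the removal of 2-(methylsulfanyl)ethyl from the saturated chain carbon bound to an amine nitrogen and a carbonyl carbon gives a 1.4-fold higher number from compound 3 to compound 4 (0.16 log units; within the scatter) and so shows that hydrogen can stand there with no change beyond the scatter. Going by these compounds alone, the only earlier step, a 2.8-fold higher number from compound 1 to compound 2 (0.45 log units; beyond the scatter), concerned a different change and said nothing about this side chain. No measurement shown gives a cause for this result. The compounds shown leave open whether a benzyl group or a 4-aminobutyl chain on this carbon would move the number beyond the scatter.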